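This account rests on a few compounds, and the source may have more. Where it says the series, first, only, none or still open, it means among the compounds named here.

In a functional assay on PC-3 cells (Homo sapiens), read by MTT assay, with a stated time of 48 h (a higher number here means a weaker inhibitor, a lower number a stronger inhibitor), compound 1 (`CCn1c(C(=O)NCCN(C)C)ccc1C(CC)(CC)c1ccc(OCC(=O)C(C)(C)C)c(C)c1`) gives 2300 nM, compound 2 (`CCOC(=O)CN(C)C(=O)c1ccc(C(CC)(CC)c2ccc(OCC(O)C(C)(C)C)c(C)c2)n1CC`) gives 25500 nM and compound 3 (`CCn1c(C(=O)NCCN(C)C)ccc1C(CC)(CC)c1ccc(OCC(O)C(C)(C)C)c(C)c1`) gives 1630 nM. Placing 1-hydroxy-2,2-dimethylpropyl where (tert-butyl)carbonyl stood gives a 1.4-fold lower number from compound 1 to compound 3 (0.15 log units; within the scatter), a change away from the amide chain. The amide substituent swap gives a 16-fold lower number from compound 2 to compound 3 (1.19 log units; beyond the scatter), a large step, but it replaces an ester-bearing group and does not alter one amine end into another. Compound 4 (`CCN(CC)CCCNC(=O)c1ccc(C(CC)(CC)c2ccc(OCC(O)C(C)(C)C)c(C)c2)n1CC`) differs from compound 3 by (diethylamino)methyl in place of dimethylamino on a saturated chain carbon, two bonds along the chain from an amide-type nitrogen, making (3-(diethylamino)propyl)amino from (2-(dimethylamino)ethyl)amino. Among the measured compounds shown here, no measured step covers such a swap, so no shift beyond the scatter is expected. The expected step is a 1.2-fold lower number from compound 3 to compound 4 (0.07 log units; within the scatter). For compound 4 the estimated value is 1400 nM, with an expected range of 500 nM to 4000 nM.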

Compound 4, half-maximal inhibitory concentration: 2500 nM
Beside the measured number, compound 4's estimate is 1.8-fold (0.25 log units) below it, and the stated range covers the measured number.
By their numbers in this assay, from the lowest: compounds 3, 1 and 4 (each within the scatter of the next); then compound 2.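

With (3-(diethylamino)propyl)amino in place of (2-(dimethylamino)ethyl)amino, the amine end of the amide chain changes in both length and alkyl groups, yet the step stays within the scatter (a 1.5-fold higher number from compound 3 to compound 4 (0.19 log units; within the scatter)). A second amine-bearing chain also gives a large step from the ester-bearing amide (a 10-fold lower number from compound 2 to compound 4 (1.01 log units; beyond the scatter)). Nothing measured here accounts for either result. Among the compounds shown here, the single step joins the two changes, so their separate contributions remain unknown. From the compounds shown here alone, it also remains open whether a primary amine, a carboxylic acid or a longer chain would fit at this end.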